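Methyl-Bearing Thiourea Chain in Place of a Phenyl-Bearing One

A few compounds are considered here, and "the series" means these few. Any claim that something is new, unique, unknown or untested is made for them only; others in the source may bear on it.

All four compounds share one core joined through a saturated chain to a terminal group. Compound 1 `C/N=C(/NC#N)NCCCCCn1nc(-c2ccccc2)ccc1=O` and compound 2 `CC/N=C(/NC#N)NCCCn1nc(-c2ccccc2)ccc1=O` differ from each other in chain length. In a functional assay on the whole organism with Rattus norvegicus as the target (on this read-out higher numbers stand for an effect only at larger amounts of compound and lower numbers for an effect already at smaller amounts), compound 1 gives 76.2 mg/kg. In this assay compound 2 gives 88.5 mg/kg. These two values sit within the usual scatter of each other. Compound 3 `O=c1ccc(-c2ccccc2)nn1CCCCNC(=S)Nc1ccccc1` carries a terminal group with the six-membered aromatic ring of carbon only. In this assay compound 3 gives only a limit, > 100 mg/kg, so its true dose is not known; it stands at the limit of > 100 mg/kg in this assay, at which 1 of the 3 values shown sits. Compound 4 `C/N=C(\S)NCCCCn1nc(-c2ccccc2)ccc1=O` differs from compound 3 by a group of 4 heavy atoms (2 carbon, 1 nitrogen, 1 sulfur; no ring) in place of a group of 9 heavy atoms (7 carbon, 1 nitrogen, 1 sulfur; one six-membered aromatic ring of carbon only), on an amine nitrogen. Going by the values given here, no measured pair shows this exact change, so its size cannot be read from a measured step. Since the compounds bearing a methyl on a terminal nitrogen, compound 1 with 76.2 mg/kg and compound 2 with 88.5 mg/kg, returned numbers, the step is expected to run towards smaller doses, beyond the scatter, at an at least 1.2-fold lower number from compound 3 to compound 4 (0.09 log units; that floor lies within the scatter). Compound 4 is estimated at 80 mg/kg, with a range from 40 mg/kg to 160 mg/kg.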

Compound 4, dose for half-maximal effect: 17.3 mg/kg
The estimate for compound 4 lay 4.6-fold (0.67 log units) above the measured number, outside the stated range (below it).
By their numbers in this assay, from the lowest: compound 4; then compounds 1 and 2 (each within the scatter of the next). At a limit, above all of these: compound 3.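

In this assay, going by these compounds alone, the change on the amine nitrogen, from the group of 9 heavy atoms with its six-membered aromatic ring of carbon only to the group of 4 heavy atoms with no ring, gives an at least 5.7-fold lower number from compound 3 to compound 4 (0.76 log units; beyond the scatter) as the first measured step at this place. On these data alone, compound 3 stands only at a limit (> 100 mg/kg) in this assay so the true size of this step stays unknown, though its direction is clear. Compound 4 also lies beyond the scatter of the other two, with a 5.1-fold lower number from compound 2 to compound 4 (0.71 log units; beyond the scatter) and a 4.4-fold lower number from compound 1 to compound 4 (0.64 log units; beyond the scatter) as steps that replace the whole chain end and so cannot separate terminal group from chain length.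

The compounds shown leave open whether an ethyl group on that nitrogen would keep the lower dose. They also leave open whether a cyclohexyl ring there would behave like the phenyl-bearing compound 3.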